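The source may hold more compounds than are shown below. What is called first, only, known or untested is meant among the compounds shown, and "the series" means these compounds.

Of the compounds shown here, two have been measured in a physicochemical assay for solubility, read by mass spectrometry, in phosphate buffer, with a stated time of 24 h, at pH 7.4; a higher number here means a more soluble compound, a lower number a less soluble compound. Compound 1 `CC[C@H](C)C(=O)N1CCC(NC(=O)Nc2ccc(OC(F)(F)F)c(OC(F)(F)F)c2)CC1` gives 5.5 ug/mL. Compound 2 `O=C(Nc1ccc(C(F)(F)F)c(F)c1)NC1CCN(C(=O)C2(C(F)(F)F)CC2)CC1` gives 0.08 ug/mL, the lowest of the two numbers; the gap up to compound 1 is large and lies beyond the usual scatter.

Compound 3 `O=C(Nc1ccc(C(F)(F)F)c(F)c1)NC1CCN(C(=O)C2CC2)CC1` has not been measured. It differs from compound 2 in one place: hydrogen in place of trifluoromethyl on a saturated ring carbon. Among the measured compounds shown here, no pair of measured compounds shows this same change, so the expectation rests on the structures alone and carries wide uncertainty. The trifluoromethyl leaves and only a hydrogen enters, and the expected step from compound 2 to compound 3 is a modest rise, a 3.8-fold higher number from compound 2 to compound 3 (0.57 log units; beyond the scatter), perhaps at the edge of the scatter. Compound 3 is therefore estimated at 0.3 ug/mL, within a range from 0.08 ug/mL to 1.5 ug/mL.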

Compound 3, solubility: 0.46 ug/mL
For compound 3 the middle estimate is 1.5-fold (0.19 log units) below the measured one, within the range that was stated.
By their numbers in this assay, from the lowest: compound 2; then compound 3; then compound 1.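

Swapping trifluoromethyl for hydrogen on a saturated ring carbon of the three-membered ring gives a 5.8-fold higher number from compound 2 to compound 3 (0.76 log units; beyond the scatter) in this assay. The two earlier compounds differ in more than one place, so they could not tie any change in the number to a single group, whereas this pair ties a step beyond the scatter to the change from 1-(trifluoromethyl)cyclopropyl to cyclopropyl alone. Nothing measured here explains why the number rises.

From the compounds shown here alone, it remains open how a methyl, an amine or a carboxylic acid on this same ring carbon would compare with hydrogen and trifluoromethyl. This is also a single pair, so it cannot tell whether the same swap would give a step of similar size on a different core.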